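The source may report more compounds than this note shows. Statements on the series, on what has been measured and on what is new or still open speak of the compounds shown alone.

Compound 1 `CNC(=O)c1cc(C(=O)N[C@H]2CC[C@H](O)CC2)c([C@@H](C)c2ccc(Cl)cc2)o1` was tested in a physicochemical assay for solubility, measured as kinetic solubility; on this read-out lower numbers stand for lower solubility and higher numbers for higher solubility. In this assay compound 1 gives >= 118 ug/mL, which is a limit of the assay rather than a number. Compound 2 `CC(=O)Nc1c(F)cc(C(=O)N[C@H]2CC[C@H](O)CC2)cc1O[C@@H](C)c1ccccc1` gives >= 159 ug/mL in this assay, again a limit. Compound 3 `CNC(=O)c1cc(C(=O)N[C@H]2CC[C@H](OC)CC2)n([C@@H](CO)c2ccccc2)n1` gives >= 164 ug/mL in this assay, also a limit. With limits throughout, compound 1 cannot be placed above or below the other two. Compound 4 `CNC(=O)c1cc(C(=O)N[C@H]2CC[C@H](O)CC2)c([C@@H](C)c2ccc(C)cc2)o1` differs from compound 1 in one place: methyl in place of chloro on an aromatic carbon. For the measured compounds named here, no measured pair shows what this change does here, so the step from compound 1 to compound 4 is expected to stay within the usual scatter, quite possibly ending at a limit again. The estimated step is a step that the limit leaves unreadable from compound 1 to compound 4. Compound 4 is therefore expected to show 120 ug/mL, between 60 ug/mL and 200 ug/mL.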

Compound 4, solubility: >= 245 ug/mL
Compound 4: only a limit was reported; the forecaster's own chance of this, stated with the estimate: 65%; at least 2.0-fold (0.30 log units) between middle value and limit.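

For the compounds shown here, compound 1 and compound 4 were both reported only as limits of the assay, so no step between them can be read. As far as these compounds go, whether methyl in place of chloro changes solubility at all, and in which direction, remains open.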